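Amide nitrogen substituents in a whole-organism inhibition series

This account rests on a few compounds, and the source may have more. Where it says the series, first, only, none or still open, it means among the compounds named here.

Compound 1 `Cn1nnnc1NC(=O)c1cc(=O)c2ccccc2o1` and compound 2 `O=C(O)CCCNC(=O)c1cc(=O)c2ccccc2o1` share one core and differ only in the group on the amide-type nitrogen. In a functional assay on the whole organism for inhibition, with Rattus norvegicus as the target, with a stated time of 30 min, at a dose of 1 mg/kg by the intravenous route (on this read-out lower numbers stand for less inhibition and higher numbers for more inhibition at the one dose given (going by the name of the read-out)), compound 1 gives 0%, and in this assay compound 2 gives 0%. The step of no change at the digits printed from compound 1 to compound 2 (within the scatter) lies within the scatter, so compound 2 stands level with compound 1 at the digits shown, with no measured effect in either.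

Compound 3 `Cn1nnc(NC(=O)c2cc(=O)c3ccccc3o2)n1` is not yet measured. It differs from compound 2 by 2-methyl-2H-tetrazol-5-yl in place of 3-carboxypropyl on an amide-type nitrogen. Among the measured compounds shown here, only one measured step bears on this exchange at the amide-type nitrogen, namely no change at the digits printed from compound 1 to compound 2 (within the scatter), which swapped the 1-methyl-1H-tetrazol-5-yl of compound 1 for the 3-carboxypropyl of compound 2 without a change beyond the scatter. Compound 3 restores a methyltetrazolyl group there, so for compound 3 the expected step is no change at the digits printed from compound 2 to compound 3 (within the scatter), none beyond the scatter. The estimate for compound 3 in this assay is 0%, expected to fall between 0% and 12%.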

Compound 3, a percentage reported as inhibition, in the whole organism at one dose (the size of the read-out at that dose, not a potency): 25%
For compound 3 the middle estimate is 25 percentage points below the measured one; the measured number lies above the stated range.
By their numbers in this assay, from the lowest: compounds 1 and 2 (each within the scatter of the next); then compound 3.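

At the amide-type nitrogen, where compounds 1 and 2 gave no separation, this assay now shows a number 25 percentage points higher from compound 2 to compound 3 (beyond the scatter) as 2-methyl-2H-tetrazol-5-yl replaces 3-carboxypropyl, so the read-out does respond to the group at this position. The tetrazolyl pair is more telling: a number 25 percentage points higher from compound 1 to compound 3 (beyond the scatter) on exchange of 1-methyl-1H-tetrazol-5-yl for 2-methyl-2H-tetrazol-5-yl, so within these compounds the presence of a methyltetrazolyl group does not by itself decide the outcome. Only the particular 2-methyl-2H-tetrazol-5-yl group gives a read-out separated from the other two.

Open, on these data alone, is whether an unsubstituted tetrazol-5-yl or a 2-ethyl-2H-tetrazol-5-yl group on the amide-type nitrogen would keep or extend this effect. A single dose also leaves the potency of compound 3 undefined. No supporting measurement is available to explain the difference between these groups.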